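The source may report more compounds than this note shows. Statements on the series, on what has been measured and on what is new or still open speak of the compounds shown alone.

Of the compounds shown here, three that share one core have been measured in a physicochemical assay for lipophilicity; a lower number here means a more polar compound, a higher number a more lipophilic compound. Compound 1, `C[n+]1ccn(CCN2CCCCC2)c1/C=N/O`, gives -2.32. Compound 3, `CC[n+]1ccn(CCN(C)S(=O)(=O)C(F)(F)F)c1/C=N/O`, gives -1.19. Compound 2, `CCN(CCn1cc[n+](C)c1/C=N/O)S(C)(=O)=O`, gives -2.72, the lowest of the three numbers: compound 1 lies nearest, above it by a gap beyond the usual scatter, and compound 3 lies furthest, far beyond the scatter.

Compound 4, `CCN(CCn1cc[n+](C)c1/C=N/O)S(=O)(=O)c1ccccc1`, has not yet been measured. It differs from compound 2 in one place: phenyl in place of methyl on a sulfonyl sulfur. Within the data shown here, no measured pair here differs by this exchange alone, so there is no measured step to lean on. The expected step is a number 1.72 log units higher from compound 2 to compound 4 (beyond the scatter), a rise clearly beyond the scatter. Compound 4 is therefore estimated at -1, with a range from -1.6 to -0.4.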

Compound 4, distribution coefficient: -1.39
Compound 4: middle estimate off by 0.39 log units, on the high side, within the range that was stated.
By their numbers in this assay, from the lowest: compound 2; then compound 1; then compounds 4 and 3 (each within the scatter of the next).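

Placing phenyl in place of methyl on a sulfonyl sulfur gives the first measured step at this position: in this assay the result is a number 1.33 log units higher from compound 2 to compound 4 (beyond the scatter), a large change. The number at this position therefore responds strongly to the group on the sulfur, even though this exchange adds no hydrogen-bond donors or acceptors. Nothing measured here accounts for the size of this step.

Still open, from the compounds shown here alone, is where an ethyl chain or a benzyl group on the sulfonyl sulfur would fall. Also open, going by these compounds, is whether a pyridine ring would give a step like that of phenyl.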